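A few compounds are considered here, and "the series" means these few. Any claim that something is new, unique, unknown or untested is made for them only; others in the source may bear on it.

Compound 1 `COc1ccc(-c2cc(=O)c3c(OC)cc(OC)cc3n2C)cc1` in a functional assay on KOPN-8 cells (Homo sapiens) for antiproliferative activity, with a stated time of 72 h (on this read-out higher numbers stand for an effect only at larger amounts of compound and lower numbers for an effect already at smaller amounts), gives 30000 nM, the higher of the two numbers at hand; the nearest is compound 2 `COc1ccc(-c2c(Br)c(=O)c3c(OC)cc(OC)cc3n2S(=O)(=O)c2ccc(OC)cc2)cc1` with 2580 nM. For compound 3 `COc1ccc(-c2cc(=O)c3c(OC)cc(OC)cc3n2S(=O)(=O)c2ccc(F)cc2)cc1` only a limit of the assay is reported, > 65500 nM. The step of an at least 2.1-fold higher number from compound 1 to compound 3 (0.33 log units; beyond the scatter) is the one closest to the present change, and its size is bounded only by the limit of > 65500 nM in this assay, at which 1 of the 3 values shown sits.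

Compound 4 `COc1ccc(-c2cc(=O)c3c(OC)cc(OC)cc3n2S(=O)(=O)c2cccc(Br)c2)cc1` differs from compound 1 by (3-bromophenyl)sulfonyl in place of methyl on an aromatic nitrogen. Given the step to compound 3, a comparable rise in this assay is expected, a 2.0-fold higher number from compound 1 to compound 4 (0.30 log units; within the scatter), with a real chance that again only a limit is returned. Compound 4 is therefore estimated at 60000 nM, within 20000 nM to 200000 nM.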

Compound 4, half-maximal effective concentration: > 58600 nM
Compound 4 gave a limit, no number; the forecaster's own chance of this, stated with the estimate: 50%; the middle value is on the limit's open side.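

In this assay, compound 4 gives > 58600 nM, a limit and not a number. A second arylsulfonyl group in place of methyl on the aromatic nitrogen therefore again yields no number, now with 3-bromophenyl on the sulfonyl sulfur, and the reading is an at least 1.9-fold higher number from compound 1 to compound 4 (0.29 log units; that floor lies within the scatter). The step between compound 3 and compound 4 cannot be read, since both values are limits.

Open, going by these compounds, is whether an amine or a carboxylic acid on the sulfonyl's phenyl ring would return a number in this assay. Also open, on these data alone, is how a longer alkyl chain in place of methyl on that nitrogen would read.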